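A few compounds are considered here, and "the series" means these few. Any claim that something is new, unique, unknown or untested is made for them only; others in the source may bear on it.

Compound 1 `CCN1CCc2c(sc(NC(=O)Nc3ccc(Cl)cc3)c2C#N)C1` is tested in a functional assay (strain AB) with Danio rerio as the target, read by microscopy, with a stated time of 1 h (a higher number here means that more compound is needed for the effect, a lower number that less compound is needed), where the read-out is a half-maximal effective concentration. In this assay compound 1 gives > 25000 nM, which is a limit of the assay and not a number. That places compound 1 at the limit of > 25000 nM in this assay, at which 1 of the 2 values shown sits. Among the compounds with values here, the only true number so far belongs to compound 2 `C[N+]1(CC2CC2)CCc2c(sc(NC(=O)Nc3ccc(Cl)cc3)c2C(N)=O)C1`, and in this assay compound 2 gives 360 nM.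

Compound 3 `CCN1CCc2c(sc(NC(=O)Nc3ccc(Cl)cc3)c2C(=O)c2nnco2)C1` keeps the rest of compound 1 but changes one group on an aromatic carbon, where cyano gives way to a larger group with a five-membered aromatic ring: a group of 7 heavy atoms (3 carbon, 2 nitrogen, 2 oxygen; one five-membered aromatic ring with 3 hetero atoms) in place of a group of 2 heavy atoms (1 carbon, 1 nitrogen; no ring), on an aromatic carbon. Within the data shown here, no measured step shows what this exchange does, so any forecast is uncertain. Among the measured compounds shown here, compound 2, at 360 nM, shows only that a measurable value is reachable in this assay. A large step towards less compound needed is therefore expected, though compound 3 could also stay at the limit. The estimated change is an at least 12-fold lower number from compound 1 to compound 3 (1.09 log units; beyond the scatter). For compound 3 the expected value is 2000 nM, with an estimated range from 200 nM to 25000 nM.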

Compound 3, half-maximal effective concentration: > 25000 nM
Compound 3: a limit, no number; the forecaster's own chance of this, stated with the estimate: 25%; middle value at least 12-fold (1.09 log units) from the limit.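

In this assay, within the data shown here, compound 1 and compound 3 each give only a limit of the assay, not a number, so no step from cyano to the larger group can be read between them. The result stands as follows: the limit of > 25000 nM in this assay, at which 2 of the 3 values shown sit. Still open, on these data alone, is whether any other group in that place on the shared core gives a measurable value.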